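From Fluoro to Hydroxy on a Shared Core

The source may hold more compounds than are shown below. What is called first, only, known or untested is meant among the compounds shown, and "the series" means these compounds.

The two measured compounds share one core and differ only in the group on the pendant aromatic ring. Compound 1 `Cc1nn(C)c2c1C(c1cccc(Cl)c1)=NCCN2` carries a chloro group; in a functional assay on the whole organism for positive allosteric modulation, with Rattus norvegicus as the target (on this read-out lower numbers stand for an effect already at smaller amounts and higher numbers for an effect only at larger amounts of compound), compound 1 gives 0.63 mg/kg. Compound 2 `Cc1nn(C)c2c1C(c1cccc(F)c1)=NCCN2` carries a fluoro group instead, and in this assay compound 2 gives 2.5 mg/kg, the higher of the two numbers; the step between them is a 4.0-fold higher number from compound 1 to compound 2 (0.60 log units; beyond the scatter). Compound 3 `Cc1nn(C)c2c1C(c1cccc(O)c1)=NCCN2` has not yet been measured. It differs from compound 2 as follows: hydroxy in place of fluoro on an aromatic carbon. Among the measured compounds shown here, no measured step involves a hydroxy group, so the only guide is that exchanging chloro for fluoro already moved the number by a 4.0-fold higher number from compound 1 to compound 2 (0.60 log units; beyond the scatter). A further step of similar size in the same direction is therefore expected, though with wide uncertainty. For compound 3 in this assay the estimate is 5 mg/kg, with a range from 1.5 mg/kg to 16 mg/kg. This estimate corresponds to an expected step of a 2.0-fold higher number from compound 2 to compound 3 (0.30 log units; within the scatter).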

Compound 3, minimum effective dose: 2.5 mg/kg
Compound 3: the middle estimate sits 2.0-fold (0.30 log units) above what was measured; the measured number falls inside the stated range.
By their numbers in this assay, from the lowest: compound 1; then compounds 2 and 3 (each within the scatter of the next).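

In this assay, hydroxy in place of fluoro gives no change at the digits printed from compound 2 to compound 3 (within the scatter) even though the hydroxy group brings a hydrogen-bond donor and a hydrogen-bond acceptor and the fluoro group brings neither, so that difference in counts goes with no visible shift here. Hydroxy in place of chloro gives a 4.0-fold higher number from compound 1 to compound 3 (0.60 log units; beyond the scatter), which leaves the chloro group of compound 1 as the only one of the three substituents on this aromatic carbon with a number set apart beyond the scatter. Nothing shown here accounts for why chloro stands apart from fluoro and hydroxy.

Still open, going by these compounds, is whether bromo, methoxy, an amine or a carboxylic acid on this carbon would group with chloro or with fluoro and hydroxy. On these data alone, it is also open whether these three groups would keep the same order elsewhere on the ring.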